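Closing a Ring on the Triple-Bonded Carbon Substituent

The source may hold more compounds than are shown below. What is called first, only, known or untested is meant among the compounds shown, and "the series" means these compounds.

Compound 1 `COc1cc[nH]c1/C=C1\C(=O)Nc2ccc(F)c(C#C[C@H](N)CO)c21` gives 320 nM in a functional assay on MDA-MB-435 cells (Homo sapiens) for inhibition; a lower number here means a stronger inhibitor, a higher number a weaker inhibitor.
Compound 2 `CN[C@H](C#Cc1c(F)ccc2c1/C(=C/c1[nH]ccc1OC)C(=O)N2)CO` gives 349 nM in this assay.
Compound 3 `COc1cc[nH]c1/C=C1\C(=O)Nc2ccc(F)c(C#C[C@@H](N)[C@@H](C)O)c21` gives 300 nM in this assay.

Compound 2 shows the largest of the three numbers, but every step separating it from the others lies within the scatter: a 1.1-fold higher number from compound 1 to compound 2 (0.04 log units; within the scatter) and a 1.2-fold lower number from compound 2 to compound 3 (0.07 log units; within the scatter). Compound 4 `COc1cc[nH]c1/C=C1\C(=O)Nc2ccc(F)c(C#C[C@@H]3C[C@@H](O)CN3)c21` differs from compound 2 at the same position: 4-hydroxypyrrolidin-2-yl in place of 2-hydroxy-1-(methylamino)ethyl on a triple-bonded carbon.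

Going by the values given here, two measured steps touch this position. The step of a 1.1-fold higher number from compound 1 to compound 2 (0.04 log units; within the scatter) shows that adding a methyl on the nitrogen does not move the number, and the step of a 1.1-fold lower number from compound 1 to compound 3 (0.03 log units; within the scatter) shows the same for a methyl on the carbon bearing the hydroxyl. Neither step closes a ring, so the change to compound 4 is not covered directly; what the three compounds show is that this substituent tolerates small variation without a shift beyond the scatter in this assay.

Compound 4 is therefore expected to give about 350 nM, in a range from 150 nM to 850 nM. That corresponds to an expected step of a 1.0-fold higher number from compound 2 to compound 4 (0.00 log units; within the scatter).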

Compound 4, half-maximal inhibitory concentration: 63 nM
Compound 4: the middle estimate sits 5.6-fold (0.74 log units) above what was measured; the measured number lies below the stated range.
By their numbers in this assay, from the lowest: compound 4; then compounds 3, 1 and 2 (each within the scatter of the next).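

Closing the substituent into a 4-hydroxypyrrolidin-2-yl ring moves the number in this assay where the open-chain variations did not, with a 5.5-fold lower number from compound 2 to compound 4 (0.74 log units; beyond the scatter), a 5.1-fold lower number from compound 1 to compound 4 (0.71 log units; beyond the scatter) and a 4.8-fold lower number from compound 3 to compound 4 (0.68 log units; beyond the scatter), each beyond the scatter. The position on the triple-bonded carbon is therefore not indifferent to every change: compounds 1, 2 and 3 sit within the scatter of one another, while compound 4 is the strongest inhibitor of the four. No evidence is available on what lies behind this result.

The change brings in a ring and a second defined stereocentre together, and the compounds shown do not separate the two. They also leave open whether the ring hydroxyl matters, which a plain pyrrolidin-2-yl would test, and how a piperidin-2-yl would compare.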